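Dithiocarbamate benzamides: piperidine to indoline step

This account rests on a few compounds, and the source may have more. Where it says the series, first, only, none or still open, it means among the compounds named here.

Measured so far:
- compound 1 `CC1CCCCN1C(=S)SCc1ccc(C(=O)Nc2ccccc2N)cc1`, in a functional assay on HeLa cells (Homo sapiens) for antiproliferative activity, read by CCK-8 assay, with a stated time of 72 h, tested at 8 uM (on this read-out lower numbers stand for a weaker effect and higher numbers for a stronger effect at the one concentration tested), compound 1 gives 76.3%
- compound 2 `Nc1ccccc1NC(=O)c1ccc(CSC(=S)N2CCN(Cc3ccncc3)CC2)cc1`, in this assay compound 2 gives 72.9%

Compound 1 stands highest of the two numbers, but compound 2 lies within the scatter of it, so the two cannot be ordered. Within the data shown here, no single-change step between measured compounds is available, and the two share the core while differing in more than one place.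

Compound 3 `Nc1ccccc1NC(=O)c1ccc(CSC(=S)N2CCc3ccccc32)cc1` carries 2,3-dihydro-1H-indol-1-yl in place of 2-methylpiperidin-1-yl on a thiocarbonyl carbon. Among the measured compounds shown here, with no comparable step among the measured compounds, no direction can be inferred from the data; the expectation is a step of a number 4.3 percentage points lower from compound 1 to compound 3 (within the scatter), that is, none beyond the scatter. Compound 3 is therefore estimated at 72% in this assay, with a range from 55% to 86%.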

Compound 3, a percentage reported as inhibition, at one concentration (the size of the read-out at that concentration, not a potency): 67%
For compound 3 the middle estimate is 5 percentage points above the measured one; the range from low to high includes it.
By their numbers in this assay, from the lowest: compounds 3, 2 and 1 (each within the scatter of the next).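

Among these compounds, on the thiocarbonyl carbon, the first single-change step, 2,3-dihydro-1H-indol-1-yl in place of 2-methylpiperidin-1-yl, reads a number 9.3 percentage points lower from compound 1 to compound 3 (within the scatter) in this assay and so does not separate the two groups at the one concentration tested. At this position, a six-membered non-aromatic ring can thus give way to a five-membered non-aromatic ring with a six-membered aromatic ring of carbon only, without a change beyond the scatter. No available measurement bears on why the two groups read as they do.

The compounds shown leave open whether morpholin-4-yl or an open-chain diethylamino group on the thiocarbonyl carbon would read beyond the scatter of these groups. Also open, going by these compounds, is whether a methoxy group on the aromatic ring of 2,3-dihydro-1H-indol-1-yl would move the read-out away from that of compound 3.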